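The source may hold more compounds than are shown below. What is called first, only, known or untested is meant among the compounds shown, and "the series" means these compounds.

Compound 1 `COc1ccc(C(=O)c2sc3nc(-c4cccs4)ccc3c2N)cc1`: in a functional assay on WI-38 VA13 cells (Homo sapiens) for cytotoxicity (a lower number here means that less compound is needed, a higher number that more compound is needed for the effect), compound 1 gives 0.77 ug/mL.
Compound 2 `CCOC(=O)c1sc2nc(-c3cccs3)ccc2c1N`: in this assay compound 2 gives > 4 ug/mL, which is a limit of the assay and not a number.
Compound 3 `CC(C)(C)C(=O)c1sc2nc(-c3cccs3)ccc2c1N`: in this assay compound 3 gives 0.57 ug/mL.

Of the two numbers shown, compound 3 has the lowest, and its nearest neighbour is compound 1; the step of a 1.4-fold lower number from compound 1 to compound 3 (0.13 log units; within the scatter) lies within the scatter, so the two cannot be told apart. Compound 2 sits at the limit of > 4 ug/mL in this assay, at which 1 of the 3 values shown sits. The two steps that reach beyond the scatter both involve the ethoxy compound: an at least 5.1-fold higher number from compound 1 to compound 2 (0.71 log units; beyond the scatter) and an at least 7.0-fold lower number from compound 2 to compound 3 (0.84 log units; beyond the scatter).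

Compound 4 `COc1cccc(C(=O)c2sc3nc(-c4cccs4)ccc3c2N)c1` differs from compound 3 in one place: 3-methoxyphenyl in place of tert-butyl on a carbonyl carbon. The step that bears most directly on this change is a 1.4-fold lower number from compound 1 to compound 3 (0.13 log units; within the scatter), which, read in the opposite direction, shows that replacing tert-butyl with a methoxyphenyl on the carbonyl carbon moved the number by less than the scatter. For the measured compounds named here, no measured pair compares a 3-methoxyphenyl with anything, and the ethoxy steps do not touch it. The expectation is therefore a 1.2-fold higher number from compound 3 to compound 4 (0.09 log units; within the scatter), nothing beyond the scatter. Compound 4 is estimated at 0.7 ug/mL, within a range from 0.3 ug/mL to 1.8 ug/mL.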

Compound 4, half-maximal effective concentration: 0.03 ug/mL
Compound 4: the middle estimate sits 23-fold (1.37 log units) above what was measured; measured number below the stated range.
By their numbers in this assay, from the lowest: compound 4; then compounds 3 and 1 (each within the scatter of the next). At a limit, above all of these: compound 2.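

The earlier compounds shown here gave no sign that the group on this carbonyl carbon could take the number far below that of tert-butyl, yet in this assay 3-methoxyphenyl gives a 19-fold lower number from compound 3 to compound 4 (1.28 log units; beyond the scatter), and against ethoxy it gives an at least 130-fold lower number from compound 2 to compound 4 (2.12 log units; beyond the scatter). Compound 1 had made an aryl group on this carbon look no different from tert-butyl, but exchanging 4-methoxyphenyl for 3-methoxyphenyl gives a 26-fold lower number from compound 1 to compound 4 (1.41 log units; beyond the scatter), so an aromatic ring here does not by itself set the number and the place of the methoxy on that ring counts. Compound 2 stands at a limit of the assay and not at a number, so its step gives only a bound: the limit of > 4 ug/mL in this assay, at which 1 of the 4 values shown sits.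

The compounds shown leave open whether the methoxy group itself is needed, since a plain phenyl or a 2-methoxyphenyl on this carbonyl carbon would be required to separate its presence from its place. They also leave open whether a 3-aminophenyl or a 3-ethoxyphenyl group would follow 3-methoxyphenyl, and whether the step would hold on a core other than the shared one.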